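The source may report more compounds than this note shows. Statements on the series, on what has been measured and on what is new or still open speak of the compounds shown alone.

Of the compounds shown here, two built on one shared core have been measured in a functional assay on HeLa cells (Homo sapiens) for inhibition; a higher number here means a weaker inhibitor, a lower number a stronger inhibitor. Compound 1, `Oc1cccc(-c2cc(-c3cccc(F)c3)cc(-c3ccccc3O)n2)c1`, gave > 50000 nM, which is a limit of the assay rather than a number. Going by the values given here, compound 2, `Oc1ccc(-c2cc(-c3ccccc3F)cc(-c3cccc(O)c3)n2)cc1`, gave 14300 nM in this assay, and that is the only number among the values shown. The other value sits at the limit of > 50000 nM in this assay, at which 1 of the 2 values shown sits. Among the compounds with values here, these two compounds differ in more than one place, and no step between them is counted. Within the data shown here, their values show only that compound 2 yields a number where compound 1 does not.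

Compound 3, `Oc1ccc(-c2cc(-c3cccc(F)c3)cc(-c3cccc(O)c3)n2)cc1`, has the same atoms as compound 2, joined differently: 3-fluorophenyl in place of 2-fluorophenyl on an aromatic carbon. The group that leaves and the group that enters are each a six-membered aromatic ring of carbon only bearing one fluorine, and the exchange sits on an aromatic carbon of a six-membered aromatic ring with 1 nitrogen, opposite the ring nitrogen. Among the measured compounds shown here, no measured pair isolates this change. The step of a 1.4-fold higher number from compound 2 to compound 3 (0.15 log units; within the scatter) is expected to stay within the usual scatter or lean slightly toward weaker inhibition. Compound 3 is therefore estimated at 20000 nM in this assay, with a range from 7000 nM to 50000 nM.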

Compound 3, half-maximal inhibitory concentration: 14200 nM
The estimate for compound 3 lay 1.4-fold (0.15 log units) above the measured number, and the stated range covers the measured number.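

In this assay, 3-fluorophenyl in place of 2-fluorophenyl gives a 1.0-fold lower number from compound 2 to compound 3 (0.00 log units; within the scatter), so at this position, opposite the ring nitrogen, the two fluorophenyl groups cannot be told apart in this assay. Elsewhere on the shared core, 4-hydroxyphenyl in place of 2-hydroxyphenyl gives an at least 3.5-fold lower number from compound 1 to compound 3 (0.54 log units; beyond the scatter), the only step shown that lies beyond the scatter, which means that a change at this other place can be seen where the fluorine change at the first place cannot. That step can be read only as a minimum because compound 1 carries a limit and not a number: the limit of > 50000 nM in this assay, at which 1 of the 3 values shown sits.

The compounds shown leave open whether anything other than a fluorophenyl group would alter the result at the position opposite the ring nitrogen, such as a phenyl ring bearing an amine or a carboxylic acid, or a 4-fluorophenyl group. They also leave open whether the hydroxyl groups themselves matter, which a methoxy group in their place would test, and whether the hydroxyphenyl change would give a similar step alongside 2-fluorophenyl.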